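Series notes: varying the group on a saturated ring carbon

The source may report more compounds than this note shows. Statements on the series, on what has been measured and on what is new or still open speak of the compounds shown alone.

Measured so far, in a functional assay on EKVX cells (Homo sapiens) for antiproliferative activity, with a stated time of 48 h; on this read-out higher numbers stand for weaker inhibition of growth and lower numbers for stronger inhibition of growth:
compound 1 `Cc1cc(O)c(C2=NN(c3ccc(S(N)(=O)=O)cc3)C(c3ccccc3O)C2)cc1Cl`: 7160 nM
compound 2 `Cc1cc(O)c(C2=NN(c3ccc(S(N)(=O)=O)cc3)C(/C=C/c3ccccc3)C2)cc1Cl`: 35300 nM

Among the compounds with values here, compound 2 holds the higher of the two numbers; the only measured step, a 4.9-fold higher number from compound 1 to compound 2 (0.69 log units; beyond the scatter), separates it from compound 1. Compound 3 `COc1ccc(C2CC(c3cc(Cl)c(C)cc3O)=NN2c2ccc(S(N)(=O)=O)cc2)cc1OC` keeps the shared core of compound 2 and changes it at one place: 3,4-dimethoxyphenyl in place of 2-phenylethenyl on a saturated ring carbon. The measured step bears on this in part: compound 1 carries a six-membered aromatic ring of carbon only on a saturated ring carbon, as compound 3 does, while compound 2 carries the 2-phenylethenyl group there, and a 4.9-fold higher number from compound 1 to compound 2 (0.69 log units; beyond the scatter) shows the number rising when that group is present. Within the data shown here, no measured pair shows a 3,4-dimethoxyphenyl group, nor the absence of the hydroxyl of 2-hydroxyphenyl, so how far the number returns is open. Compound 3 is therefore expected to move back toward the lower number without reaching it, an estimated step of a 2.7-fold lower number from compound 2 to compound 3 (0.43 log units; beyond the scatter). For compound 3 the estimate in this assay is 13000 nM, within 4500 nM to 40000 nM.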

Compound 3, concentration for total growth inhibition: 100000 nM
The estimate for compound 3 lay 7.7-fold (0.89 log units) below the measured number; measured number above the stated range.
By their numbers in this assay, from the lowest: compound 1; then compound 2; then compound 3.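

In this assay, 3,4-dimethoxyphenyl in place of 2-phenylethenyl on the saturated ring carbon gives a 2.8-fold higher number from compound 2 to compound 3 (0.45 log units; beyond the scatter) and so moves the number further up, not back toward compound 1, although the leaving and entering groups each carry one six-membered aromatic ring of carbon only. A six-membered aromatic ring of carbon only on this carbon therefore does not in itself keep the number low, and what the ring carries counts: 3,4-dimethoxyphenyl in place of 2-hydroxyphenyl gives a 14-fold higher number from compound 1 to compound 3 (1.15 log units; beyond the scatter) as the largest step in the series. The three groups now order as 2-hydroxyphenyl, 2-phenylethenyl and 3,4-dimethoxyphenyl from the lowest number to the highest, with every step beyond the scatter, and no available evidence accounts for this order.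

The compounds shown leave open whether the rise from compound 1 to compound 3 follows from the two methoxy groups or from the missing hydroxyl, a question that an unsubstituted phenyl group on the same carbon would help to separate. Also open, on these data alone, is how an aminophenyl or carboxyphenyl group would read at this position.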